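The compounds below may be only part of what the source reports. "The series", "measured", "known", "first", "only" and "open" are said of these compounds alone.

Compound 1 `CC(C)[C@H](NC(=O)COc1cccc2ccccc12)C(=O)N[C@@H](CC(=O)O)C(=O)COc1ccccc1`: 14000 nM
Compound 2 `CC(C)[C@H](NC(=O)COc1cccc2ccccc12)C(=O)N[C@@H](CC(=O)O)C(=O)COc1ccccc1C(F)(F)F`: > 100000 nM

In a functional assay on Jurkat cells (Homo sapiens) (a lower number here means a stronger inhibitor, a higher number a weaker inhibitor), compound 1 gives 14000 nM. Compound 2 reads > 100000 nM, and this is a limit of the assay, not a number. On these data alone, compound 2 is thus the weaker of the pair, but how much weaker is unknown.

Compound 3 `CC(C)[C@H](NC(=O)COc1cccc2ccccc12)C(=O)N[C@@H](CC(=O)O)C(=O)COc1cccc(C(F)(F)F)c1` has the same atoms as compound 2, joined differently: 3-(trifluoromethyl)phenyl in place of 2-(trifluoromethyl)phenyl on an oxygen on a saturated carbon. In words, 3-(trifluoromethyl)phenyl takes the place of 2-(trifluoromethyl)phenyl on an oxygen on a saturated carbon.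

Within the data shown here, only one measured step bears on this change: an at least 7.1-fold higher number from compound 1 to compound 2 (0.85 log units; beyond the scatter), which is beyond the scatter and comes from trifluoromethyl in place of hydrogen on an aromatic carbon. Among the measured compounds shown here, no measured step shows what moving that group does. Compound 3 still carries the group, so a full return to the level of compound 1 at 14000 nM is not the likeliest outcome, yet some recovery is expected. The expected step is an at least 2.8-fold lower number from compound 2 to compound 3 (0.45 log units; beyond the scatter), towards a lower number, and it is only a rough estimate. For compound 3 the estimated value is 35000 nM, with an expected range of 10000 nM to 100000 nM.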

Compound 3, half-maximal inhibitory concentration: > 100000 nM
Compound 3 gave a limit, no number (the forecaster's own chance of this, stated with the estimate: 35%); at least 2.8-fold (0.45 log units) between middle value and limit.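

Moving the trifluoromethyl group, with 3-(trifluoromethyl)phenyl taking the place of 2-(trifluoromethyl)phenyl, does not restore the activity of compound 1 in this assay: the result is an at least 7.1-fold higher number from compound 1 to compound 3 (0.85 log units; beyond the scatter). The loss is therefore not confined to compound 2, and both trifluoromethyl compounds shown are weaker than compound 1, which carries a plain phenyl on the same oxygen. Compound 2 and compound 3 cannot be ranked against each other and the step between them cannot be read, because each gives only a limit of the assay and not a number: the limit of > 100000 nM in this assay, at which 2 of the 3 values shown sit.

On these data alone, it remains open whether one of these two placements is worse than the other, and how far the true value of either compound lies past the limit. As far as these compounds go, it is also open whether the loss belongs to trifluoromethyl in particular, or whether a fluorine atom or a methoxy group in its place would give the same result.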